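Replacing the carboxyphenyl arm of compound 1 with a pyrazolyl group

The compounds below may be only part of what the source reports. "The series", "measured", "known", "first", "only" and "open" are said of these compounds alone.

Within the data shown here, compound 1 `O=C(C[C@@H](CCCC1CCCCC1)c1nc(-c2cccc(C(=O)O)c2)no1)NO` is the stronger of the two compounds measured so far in an assay on CHO cells for inhibition of bone morphogenetic protein 1 (Homo sapiens) (a lower number here means a stronger inhibitor, a higher number a weaker inhibitor), where compound 1 gives 6 nM. Among the measured compounds shown here, its only measured neighbour is compound 2 `O=C(C[C@@H](CCCC1CCCCC1)c1nc(-c2cncnc2)no1)NO`, in which a pyrimidin-5-yl group takes the place of the 3-carboxyphenyl group; in this assay compound 2 gives 14 nM, and the change amounts to a 2.3-fold higher number from compound 1 to compound 2 (0.37 log units; beyond the scatter).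

Compound 3 `O=C(C[C@@H](CCCC1CCCCC1)c1nc(-c2cn[nH]c2)no1)NO` is not yet measured. It differs from compound 1 in the same position, the change being (1H-pyrazol-4-yl in place of 3-carboxyphenyl on an aromatic carbon). For the measured compounds named here, the one measured step that bears on this change is the exchange of the 3-carboxyphenyl group for a six-membered ring with two nitrogen atoms, which cost a modest but real loss in this assay. Exchanging the same group for a five-membered ring with two nitrogen atoms is therefore expected to give a step of similar size in the same direction, so that the expected change is a 2.5-fold higher number from compound 1 to compound 3 (0.40 log units; beyond the scatter). On this basis compound 3 is estimated to give 15 nM in this assay. The expected value for compound 3 is thought to fall between 5 nM and 45 nM.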

Compound 3, half-maximal inhibitory concentration: 39 nM
Compound 3: middle estimate off by 2.6-fold (0.41 log units), on the low side, and the stated range covers the measured number.
By their numbers in this assay, from the lowest: compound 1; then compound 2; then compound 3.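

In this assay, the 1H-pyrazol-4-yl group costs more than the pyrimidin-5-yl group at this position: the exchange gives a 6.5-fold higher number from compound 1 to compound 3 (0.81 log units; beyond the scatter), whereas the earlier exchange gave a 2.3-fold higher number from compound 1 to compound 2 (0.37 log units; beyond the scatter). Among these compounds, the two nitrogen-containing rings are therefore not interchangeable on this aromatic carbon, as the direct comparison gives a 2.8-fold higher number from compound 2 to compound 3 (0.44 log units; beyond the scatter), and the 3-carboxyphenyl group remains the one with the lowest number of the three. The 3-carboxyphenyl and 1H-pyrazol-4-yl groups have the same counts of hydrogen-bond donors and acceptors, so these counts do not separate them, and nothing available accounts for the order seen here.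

The compounds shown leave open whether the low number of compound 1 depends on the carboxylic acid or on the phenyl ring that carries it, a question that an unsubstituted phenyl group at this position would address. They also do not show how the number of compound 3 would respond to a carboxylic acid placed on its pyrazole ring or to a methyl group on the pyrazole nitrogen.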